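Working notes: aryl change on the amino nitrogen

The source may hold more compounds than are shown below. What is called first, only, known or untested is meant among the compounds shown, and "the series" means these compounds.

Measured in a functional assay on MCF7 cells (Homo sapiens) for cytotoxicity, read by sulforhodamine B assay, with a stated time of 72 h; a lower number here means a stronger inhibitor, a higher number a weaker inhibitor:
- compound 1, `CCS(=O)(=O)Nc1cc(-c2ccc3ncnc(Nc4ccc(F)cc4)c3c2)cnc1OC`: 6510 nM
- compound 2, `CCS(=O)(=O)Nc1cc(-c2ccc3ncnc(Nc4ccc(OC)cc4)c3c2)cnc1OC`: 1790 nM
- compound 3, `CCS(=O)(=O)Nc1cc(-c2ccc3ncnc(Nc4ccc(OC)c(OC)c4)c3c2)cnc1OC`: 2430 nM

Compound 3 stands second highest of the three numbers in this assay; its nearest neighbour is compound 2 and its furthest is compound 1. The steps among the measured compounds are a 3.6-fold lower number from compound 1 to compound 2 (0.56 log units; beyond the scatter), a 2.7-fold lower number from compound 1 to compound 3 (0.43 log units; beyond the scatter) and a 1.4-fold higher number from compound 2 to compound 3 (0.13 log units; within the scatter).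

Compound 4, `CCS(=O)(=O)Nc1cc(-c2ccc3ncnc(Nc4ccc(Cl)c(C(=O)OC)c4)c3c2)cnc1OC`, differs from compound 3 by 4-chloro-3-(methoxycarbonyl)phenyl in place of 3,4-dimethoxyphenyl on a nitrogen on an aromatic ring. The measured steps bear on this only loosely: they show that swapping fluoro for methoxy on the aryl group moves the number modestly, and that a second methoxy changes little. Going by the values given here, no measured step involves chloro or a methoxycarbonyl group on this aryl ring, so the direction of the change is not anchored. The halogen-bearing aryl group of compound 1 gave the highest number, which is the only hint. The step is therefore expected to be modest and upward, a 1.6-fold higher number from compound 3 to compound 4 (0.22 log units; within the scatter), with a wide range. Compound 4 is expected to give 4000 nM in this assay, between 1300 nM and 12000 nM.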

Compound 4, half-maximal inhibitory concentration: 1430 nM
The estimate for compound 4 lay 2.8-fold (0.45 log units) above the measured number, within the range that was stated.
By their numbers in this assay, from the lowest: compounds 4, 2 and 3 (each within the scatter of the next); then compound 1.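

Notes on the aryl group on the amino nitrogen: in this assay the step of a 1.7-fold lower number from compound 3 to compound 4 (0.23 log units; within the scatter) and the step of a 1.3-fold lower number from compound 2 to compound 4 (0.10 log units; within the scatter) both stay within the scatter, so 4-chloro-3-(methoxycarbonyl)phenyl cannot be told apart here from 3,4-dimethoxyphenyl or 4-methoxyphenyl, and this place tolerates an aryl group carrying no methoxy substituent on the ring without a loss that can be read. Going by these compounds alone, the step of a 4.6-fold lower number from compound 1 to compound 4 (0.66 log units; beyond the scatter) lies beyond the scatter and removes the one hint drawn from compound 1: a halogen on this aryl group does not by itself go with the highest number, since compound 4 carries chloro and stands with compounds 2 and 3, while only the 4-fluorophenyl of compound 1 stands apart. Nothing measured explains why these aryl groups fall as they do.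

Compound 4 changes chloro and methoxycarbonyl together, so the share of each stays unresolved, and a ring carrying only one of them would be needed to separate them. Also open, on these data alone, is how this place responds to a carboxylic acid in place of the methyl ester, or to an amine on the aryl ring.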